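The source may hold more compounds than are shown below. What is called first, only, known or untested is meant among the compounds shown, and "the series" means these compounds.

Measured compounds so far:
compound 1, `COc1ccc(CNC(=N)[C@@H]2CCC(=O)N2Cc2ccccc2[N+](=O)[O-])cc1`: 18.1%
compound 2, `N=C(NCc1ccc(O)cc1)[C@@H]1CCC(=O)N1Cc1ccc(F)cc1`: 35.2%

Both compounds were tested in a functional assay on SH-SY5Y cells (Homo sapiens) for cytotoxicity, read by MTT assay, with stated times of 8 h, 30 min and 12 h, tested at 0.05 uM; a lower number here means a weaker effect, a higher number a stronger effect of the compound at the concentration tested. Among the two numbers compound 2 stands highest; the only other value, that of compound 1, lies lower by a margin beyond the usual scatter of this measurement. Going by the values given here, the two compounds differ in more than one place, so no single-change step connects them, and their values show only that compound 2 acts more strongly than compound 1 in this assay at the tested concentration.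

Compound 3, `COc1ccc(CNC(=N)[C@@H]2CCC(=O)N2Cc2ccc(F)cc2)cc1`, has not yet been measured. It differs from compound 2 in one place: methyl in place of hydrogen on an oxygen on an aromatic ring. Compound 1 already carries the methoxy group, but it also differs from compound 3 elsewhere, so it cannot by itself say what this change does. With the value of compound 1 at 18.1% as the only hint, the expected step in this assay is a small decrease, close to or just beyond the scatter. The estimated step from compound 2 to compound 3 is a number 9.2 percentage points lower from compound 2 to compound 3 (within the scatter). Compound 3 is thus expected to give about 26%, with a plausible range from 14% to 40%.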

Compound 3, a percentage reported as activity, at one concentration (the size of the read-out at that concentration, not a potency): 15.8%
Compound 3: middle estimate off by 10.2 percentage points, on the high side; measured number inside the range.
By their numbers in this assay, from the lowest: compounds 3 and 1 (each within the scatter of the next); then compound 2.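

In this assay, going by these compounds alone, with the 4-fluorophenyl group held constant, hydroxy to methoxy on the aromatic ring gives a number 19.4 percentage points lower from compound 2 to compound 3 (beyond the scatter), the first single-change comparison at this oxygen. This shows that adding one methyl at this place is enough to move the read-out by more than the usual scatter. Within the data shown here, with the methoxy group kept, 4-fluorophenyl in place of 2-nitrophenyl gives a number 2.3 percentage points lower from compound 1 to compound 3 (within the scatter), so of the two single changes now available, only the one on the oxygen separates its pair of compounds.

No available measurement explains the step at the oxygen. On these data alone, what an amino group or an ethoxy group would give at this place remains open, as does whether the same step would appear with 2-nitrophenyl in place of 4-fluorophenyl, and these single-concentration read-outs do not describe potency.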